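This account rests on a few compounds, and the source may have more. Where it says the series, first, only, none or still open, it means among the compounds named here.

Measured in an ADME assay on Huh-7 cells (Homo sapiens) for cytotoxicity, read by MTT assay, with a stated time of 4 h, at 37 degrees C; a lower number here means that less compound is tolerated, a higher number that more compound is tolerated:
Compound 1 `CCCOCCNc1nc(Oc2ccccc2)nc2[nH]c(=O)c(-c3ccc(F)cc3)cc12`: 79800 nM
Compound 2 `Cn1c(=O)c(-c2ccc(F)cc2)cc2c(N3CCCC3)nc(N)nc21`: 111000 nM
Compound 3 `CCCOCCNc1nc(N)nc2c1cc(-c1ccc(F)cc1)c(=O)n2C`: 54300 nM

In this assay, compound 3 stands apart from only one of the other two compounds. The measured change is a 2.0-fold lower number from compound 2 to compound 3 (0.31 log units; beyond the scatter), a modest step beyond the scatter, while the values of compound 1 and compound 3 lie within the scatter of each other.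

Compound 4 `CCCOCCNc1nc(N)nc2[nH]c(=O)c(-c3ccc(F)cc3)cc12` has not yet been measured. It comes from compound 3 by a single change, hydrogen in place of methyl on an aromatic nitrogen.

Among the measured compounds shown here, no measured step tests this change. For the measured compounds named here, the only step available, from compound 2 to compound 3, replaces pyrrolidin-1-yl with (2-propoxyethyl)amino on an aromatic carbon, so it concerns another place and gives no direct size. Compound 1, at 79800 nM, offers indirect support, since it has hydrogen on that aromatic nitrogen yet sits within the scatter of compound 3, though it also differs from compound 4 elsewhere. No shift beyond the scatter is therefore expected in this assay.

The estimated change is a 1.2-fold higher number from compound 3 to compound 4 (0.08 log units; within the scatter), which is expected to remain within the scatter. For compound 4 the expected value is 65000 nM, with an estimated range from 32000 nM to 130000 nM.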

Compound 4, half-maximal cytotoxic concentration: 130000 nM
Estimate against measurement, compound 4: 2.0-fold (0.30 log units) below, and the stated range covers the measured number.
By their numbers in this assay, from the lowest: compounds 3, 1, 2 and 4 (each within the scatter of the next, the first and the last beyond it).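

In this assay, hydrogen in place of methyl on the aromatic nitrogen gives a 2.4-fold higher number from compound 3 to compound 4 (0.38 log units; beyond the scatter), the only measured test of this position among these compounds, and it shows that losing this single carbon moves the number modestly beyond the scatter. This places the aromatic nitrogen alongside the aromatic carbon that carries the amine, where replacing pyrrolidin-1-yl gave a 2.0-fold lower number from compound 2 to compound 3 (0.31 log units; beyond the scatter), as a second site where one change moves the number beyond the scatter, though in the opposite direction. With hydrogen on the nitrogen, amino in place of phenoxy on an aromatic carbon gives a 1.6-fold higher number from compound 1 to compound 4 (0.21 log units; within the scatter), a step within the scatter, and no measurement shown here accounts for either result.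

The compounds shown carry only methyl or hydrogen on this nitrogen, and what an ethyl group or a longer chain ending in a carboxylic acid would do there remains open. Among the compounds shown here, it is also open whether the step keeps its size with pyrrolidin-1-yl or phenoxy on the aromatic carbons, as it is seen only in the pair carrying (2-propoxyethyl)amino and amino.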